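Swapping a chloro for an amino on a shared purine-like core

A few compounds are considered here, and "the series" means these few. Any claim that something is new, unique, unknown or untested is made for them only; others in the source may bear on it.

Of the compounds shown here, two have been tested in a functional assay on MCF7 cells (Homo sapiens) for cytotoxicity, read by sulforhodamine B assay, with a stated time of 48 h; a lower number here means a stronger inhibitor of growth, a higher number a weaker inhibitor of growth. Compound 1, with the structure `ClCc1ccccc1Cn1cnc2c(Cl)nc(Cl)nc21`, gives 1820 nM and so holds the lowest of the two numbers. Compound 2, with the structure `ClCc1cccc(Cn2cnc3nc(Cl)nc(Cl)c32)c1`, gives 4070 nM; the gap from compound 1 to compound 2 is a rise that lies beyond the usual scatter, so compound 1 is the stronger growth inhibitor of the pair.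

The next compound to be examined is compound 3, with the structure `Nc1nc(Cl)c2ncn(Cc3ccccc3CCl)c2n1`. It differs from compound 1 in one place: amino in place of chloro on an aromatic carbon, that is, an amino in place of a chloro on an aromatic carbon, sitting between two ring nitrogen atoms of the shared core. Going by the values given here, no measured pair in this set shows such an exchange, so its effect cannot be read from the numbers at hand. Because compound 1 gives 1820 nM and the rest of the molecule is untouched, compound 3 is expected to stay near it, with a step of a 1.4-fold higher number from compound 1 to compound 3 (0.14 log units; within the scatter) that may well fall within the scatter. The estimate for compound 3 is 2500 nM, within a range from 900 nM to 7000 nM.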

Compound 3, concentration for total growth inhibition: 24600 nM
For compound 3 the middle estimate is 9.8-fold (0.99 log units) below the measured one, outside the stated range (above it).
By their numbers in this assay, from the lowest: compound 1; then compound 2; then compound 3.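

In this assay the position proves far from indifferent: amino in place of chloro on this aromatic carbon, between two ring nitrogen atoms, brings a 14-fold higher number from compound 1 to compound 3 (1.13 log units; beyond the scatter), a large weakening of growth inhibition from a change of a single heavy atom. Compounds 1 and 2 both carry the chloro here, so they could say nothing about this place; the new pair shows that growth inhibition in this series depends strongly on what sits there, at least with the rest of compound 1 held fixed. Nothing measured here explains why the number rises, whether through the loss of the chloro or through the arrival of the amino with its hydrogen-bond donor and acceptor counts.

The compounds shown leave open whether other groups at this place, such as a plain hydrogen, a methoxy, a fluoro or a methylamino, would stay near compound 1 or fall towards compound 3, which could help separate those two possibilities. They also leave open whether the same exchange on compound 2 would bring a step of similar size.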